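A few compounds are considered here, and "the series" means these few. Any claim that something is new, unique, unknown or untested is made for them only; others in the source may bear on it.

Measured so far in an ADME assay on HeLa cells (Homo sapiens) for cytotoxicity, read by ATP content, with a stated time of 3 days; a higher number here means that more compound is tolerated, a lower number that less compound is tolerated:
compound 1 `N#CCCCn1c(Cn2c(=O)n(-c3ccncc3)c3ccncc32)cc2cc(Cl)ccc21` — > 50000 nM, a limit of the assay
compound 2 `NC(=O)CCCn1c(Cn2c(=O)n(C3CC3)c3ccncc32)cc2cc(Cl)ccc21` — > 50000 nM, a limit of the assay
compound 3 `N=C(CCCn1c(Cn2c(=O)n(C3CC3)c3ccncc32)cc2cc(Cl)ccc21)NO` — > 50000 nM, a limit of the assay

Compound 1 stands only at a limit in this assay, and the two further values shown are limits as well. All three sit at the limit of > 50000 nM in this assay, at which 3 of the 3 values shown sit, so nothing within the series separates one compound from another. Among the compounds with values here, the one measured step, a step that the two limits leave unreadable from compound 2 to compound 3, is left unreadable by the two limits and gives no size to carry over.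

Compound 4 `N#CCCCn1c(Cn2c(=O)n(-c3ncco3)c3ccncc32)cc2cc(Cl)ccc21` is not yet measured. It differs from compound 1 by 1,3-oxazol-2-yl in place of pyridin-4-yl on an aromatic nitrogen. No measured step touches this change, and the shared core of compound 1 has given no readable number in this assay at any of the three variations shown. The expectation for compound 4 is therefore a step that the limit leaves unreadable from compound 1 to compound 4 in this assay, that is, none beyond the scatter, with the result most likely again a limit. Compound 4 is estimated at 60000 nM, between 30000 nM and 150000 nM.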

Compound 4, half-maximal cytotoxic concentration: > 50000 nM
Compound 4: no number, only a limit; the forecaster's own chance of this, stated with the estimate: 85%; the middle value is on the limit's open side.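

No step can be read from compound 1 to compound 4, since each stands only at a limit: the limit of > 50000 nM in this assay, at which 4 of the 4 values shown sit.

The compounds shown leave open at what concentration any of them turns cytotoxic, and whether 1,3-oxazol-2-yl in place of pyridin-4-yl changes that concentration at all.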